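This account rests on a few compounds, and the source may have more. Where it says the series, first, only, none or still open, it means among the compounds named here.

In a functional assay on SK-OV-3 cells (Homo sapiens) for inhibition, read by CCK-8 assay, with a stated time of 70 h (a higher number here means a weaker inhibitor, a lower number a stronger inhibitor), compound 1 (`O=C(O)c1cccc(COc2ccc(OCCOCCNC3CCCC3)cc2)c1`) gives > 100000 nM, which is a limit of the assay and not a number. Among the measured compounds shown here, compound 2 (`OCCOCCOCCOc1ccc(OCc2ccccc2)cc1`), also without 3-carboxyphenyl, gives 59400 nM, the only numeric value so far. Compound 3 (`Nc1ccc(COc2ccc(OCCOCCNC3CCCC3)cc2)cc1`) differs from compound 1 as follows: 4-aminophenyl in place of 3-carboxyphenyl on a saturated chain carbon bound to an oxygen on an aromatic ring. No measured step sizes this change, so the expectation rests on compound 2 at 59400 nM. Expected is a moderate shift towards stronger inhibition, an at least 2.5-fold lower number from compound 1 to compound 3 (0.39 log units; beyond the scatter). For compound 3 the estimated value is 40000 nM, with an expected range of 10000 nM to 150000 nM.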

Compound 3, half-maximal inhibitory concentration: 31700 nM
For compound 3 the middle estimate is 1.3-fold (0.10 log units) above the measured one, within the range that was stated.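

In this assay, 4-aminophenyl in place of 3-carboxyphenyl on a saturated chain carbon bound to an oxygen on an aromatic ring gives an at least 3.1-fold lower number from compound 1 to compound 3 (0.49 log units; beyond the scatter). Among the compounds shown here, this is the first readable step, and it shows that the group at this position can move the read-out off the limit. The true size of the step stays unknown because compound 1 gives a limit of the assay and not a number: the limit of > 100000 nM in this assay, at which 1 of the 3 values shown sits.

On these data alone, whether the shift follows from losing the carboxylic acid or from gaining the amine remains open. A plain phenyl, 3-aminophenyl or 4-carboxyphenyl on the same carbon would separate group from ring position.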